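This account rests on a few compounds, and the source may have more. Where it says the series, first, only, none or still open, it means among the compounds named here.

Of the compounds shown here, three of one series have been measured in an ADME assay on microsomes from liver (Mus musculus, strain CD-1) for metabolic stability, read by LC-MS, tested at 2 uM; on this read-out lower numbers stand for a shorter-lived compound and higher numbers for a longer-lived compound. Compound 1 `CN1CCC(CNS(=O)(=O)c2ccccc2Nc2cc(-c3ccc4ccn(C)c4c3)c3nccnc3c2)C1` gives 0.633 h, compound 2 `Cn1cc(CNS(=O)(=O)c2ccccc2Nc2cc(-c3ccc4ccn(C)c4c3)c3nccnc3c2)cn1` gives 0.267 h, and compound 3 `CC(=O)N1CCC(NC(=O)c2ccncc2Nc2cc(-c3ccc4ccn(C)c4c3)c3nccnc3c2)CC1` gives 0.117 h. On these numbers compound 3 stands lowest of the three, the shortest-lived of the set; compound 2 is its nearest neighbour and compound 1 is furthest from it. Among the compounds with values here, the only step between two measured compounds is a 2.4-fold lower number from compound 1 to compound 2 (0.37 log units; beyond the scatter), a change on a saturated chain carbon bound to a sulfonamide nitrogen.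

The unmeasured compound 4 `CN1CCC(CNC(=O)c2ccncc2Nc2cc(-c3ccc4ccn(C)c4c3)c3nccnc3c2)C1` differs from compound 3 in one place: (1-methylpyrrolidin-3-yl)methyl in place of 1-acetylpiperidin-4-yl on an amide-type nitrogen. Within the data shown here, no measured step matches this change on an amide-type nitrogen. The step from compound 1 to compound 2 bears on it only indirectly, in that compound 1, which carries the (1-methylpyrrolidin-3-yl)methyl group, gives 0.633 h, the highest number seen. On that basis a rise is expected, of roughly a 2.6-fold higher number from compound 3 to compound 4 (0.41 log units; beyond the scatter) in this assay. Compound 4 is therefore estimated at 0.3 h, within a range from 0.12 h to 0.8 h.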

Compound 4, half-life: > 1 h
Compound 4 gave a limit, no number (the forecaster's own chance of this, stated with the estimate: 5%); at least 3.3-fold (0.52 log units) between middle value and limit.
By their numbers in this assay, from the lowest: compound 3; then compound 2; then compound 1. At a limit, above all of these: compound 4.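

On the amide-type nitrogen, (1-methylpyrrolidin-3-yl)methyl in place of 1-acetylpiperidin-4-yl gives an at least 8.5-fold higher number from compound 3 to compound 4 (0.93 log units; beyond the scatter) in this assay, which shows that the group at this position can shift the half-life strongly. Compound 4 gives a limit of the assay, not a number: the limit of > 1 h in this assay, at which 1 of the 4 values shown sits. The size of this step therefore has a lower bound only, and the earlier step, on a sulfonamide nitrogen, said nothing directly about this amide-type nitrogen.

The change alters several features at once, including the ring size, the acetyl or methyl group on the ring and the extra chain carbon, and these compounds cannot show which of them matters. A 1-methylpiperidin-4-yl group on the same nitrogen would keep the six-membered ring of compound 3 while replacing its acetyl with methyl, and so begin to separate these features.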